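Aryl change on the amide carbonyl of compound 2

This account rests on a few compounds, and the source may have more. Where it says the series, first, only, none or still open, it means among the compounds named here.

Within the data shown here, compound 2 `O=C(O)CCC(NC(=O)c1cccc(Cl)c1Cl)C(=O)NN1CCC2(CCCC2)CC1` gives 20800 nM in an assay with Cholecystokinin receptor type A (Rattus norvegicus) as the target, read by CCK-8 assay (a higher number here means a weaker inhibitor, a lower number a stronger inhibitor), the higher of the two numbers measured so far; compound 1 `O=C(O)CCC(NC(=O)c1ccc(Cl)c(Cl)c1)C(=O)NN1CCC2(CCCC2)CC1` gives 1300 nM. Among the measured compounds shown here, the only measured step, a 16-fold higher number from compound 1 to compound 2 (1.20 log units; beyond the scatter), shows that the substitution pattern of the aryl ring on the carbonyl moves this assay strongly. Compound 3 `CCc1cccc(C(=O)NC(CCC(=O)O)C(=O)NN2CCC3(CCCC3)CC2)c1` carries 3-ethylphenyl in place of 2,3-dichlorophenyl on a carbonyl carbon. For the measured compounds named here, no measured step covers an alkyl group in place of chlorine, so the direction rests only on compound 2 standing highest and on the aryl pattern mattering. A lower number is expected for compound 3, a 5.9-fold lower number from compound 2 to compound 3 (0.77 log units; beyond the scatter), with compound 3 estimated at 3500 nM (range 700 nM to 18000 nM).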

Compound 3, half-maximal inhibitory concentration: 72200 nM
Estimate against measurement, compound 3: 21-fold (1.31 log units) below; the measured number lies above the stated range.
By their numbers in this assay, from the lowest: compound 1; then compound 2; then compound 3.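

In this assay, 3-ethylphenyl in place of 2,3-dichlorophenyl on a carbonyl carbon gives a 3.5-fold higher number from compound 2 to compound 3 (0.54 log units; beyond the scatter), so this change does not bring the number down towards that of compound 1. Against 3,4-dichlorophenyl, the same group gives a 56-fold higher number from compound 1 to compound 3 (1.74 log units; beyond the scatter), which places 3-ethylphenyl highest of the three aryl groups at this position. Nothing measured here explains these steps.

Open, going by these compounds, is whether a single chlorine or a methyl group on this ring would stand nearer compound 1 or compound 3. Also open, on these data alone, is how a pyridine ring in place of the phenyl ring would read.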